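A few compounds are considered here, and "the series" means these few. Any claim that something is new, unique, unknown or untested is made for them only; others in the source may bear on it.

Compound 1 `Cc1ccc(SCc2ccc(C(=O)Nc3ccccc3N)cc2)cc1` gives 67%
Compound 2 `Nc1ccccc1NC(=O)c1ccc(CSc2ccc(Br)cc2)cc1` gives 6.17%
Compound 3 `Nc1ccccc1NC(=O)c1ccc(CSCCc2ccccc2)cc1` gives 69.9%

In a functional assay on A-375 cells (Homo sapiens) for inhibition, read by CCK-8 assay, with a stated time of 72 h, tested at 8 uM (on this read-out lower numbers stand for less inhibition of growth and higher numbers for more inhibition of growth at the one concentration tested), compound 3 (69.9%) sits at the upper end together with compound 1, the two lying within the scatter of each other, while compound 2 lies far lower. The next compound is compound 4 (`Nc1ccccc1NC(=O)c1ccc(CSc2ccc(Cl)cc2)cc1`), which carries 4-chlorophenyl in place of phenethyl on a sulfur. Going by the values given here, three measured steps bear on this change. Phenethyl and 4-methylphenyl are not told apart, with a number 2.9 percentage points higher from compound 1 to compound 3 (within the scatter) (within the scatter). Phenethyl and 4-bromophenyl are sharply separated, with a number 63.7 percentage points higher from compound 2 to compound 3 (beyond the scatter) (large). The exchange of methyl for bromo gives a number 60.8 percentage points lower from compound 1 to compound 2 (beyond the scatter) (also large). Chloro itself has not been measured, so these steps only bracket compound 4, and it could fall near either compound 1 or compound 2. A sizeable fall is therefore expected, though its size is poorly fixed, and the estimate is a number 39.9 percentage points lower from compound 3 to compound 4 (beyond the scatter) (expected). For compound 4 the expected value is 30% (estimated range 5% to 70%).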

Compound 4, percent growth inhibition at one concentration: 48.6%
Estimate against measurement, compound 4: 18.6 percentage points below; low and high end bracket the measured number.
By their numbers in this assay, from the lowest: compound 2; then compound 4; then compounds 1 and 3 (each within the scatter of the next).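

In this assay, chloro in place of bromo on the aromatic carbon gives a number 42.4 percentage points higher from compound 2 to compound 4 (beyond the scatter), so these two halogens are far from interchangeable here. Chloro is also separated from methyl, with a number 18.4 percentage points lower from compound 1 to compound 4 (beyond the scatter), and 4-chlorophenyl is separated from phenethyl on the sulfur, with a number 21.3 percentage points lower from compound 3 to compound 4 (beyond the scatter), so this group takes a middle place, clear of both the high and low ends of the series. Nothing available explains this order of bromo, chloro and methyl.

From the compounds shown here alone, it remains open whether a fluoro or a methoxy on the same aromatic carbon, or a phenyl with no such group, would fit this order. Going by these compounds, it is equally open how a shorter or longer chain between the sulfur and the phenyl would compare with phenethyl.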